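The source may hold more compounds than are shown below. What is called first, only, known or untested is meant among the compounds shown, and "the series" means these compounds.

Measured in an ADME assay on Vero cells (Chlorocebus sabaeus) for cytotoxicity, read by neutral red uptake, tested at 98 ug/mL; on this read-out lower numbers stand for a stronger effect and higher numbers for a weaker effect at the one concentration tested:
- compound 1 `O=C1CSC(c2c(Cl)cccc2Cl)N1CCN1CCCCC1` gives 76%
- compound 2 `COc1ccc(C2SCC(=O)N2CCN2CCCCC2)cc1` gives 89%
- compound 3 `O=C1CSC(c2cccc(Cl)c2)N1CCN1CCCCC1` gives 100%

Compound 3 stands highest of the three numbers in this assay, that is, with the weakest effect. Its nearest neighbour is compound 2, lower by an amount beyond the scatter; compound 1 is furthest, lower by a larger amount, also beyond the scatter. No pair among these three differs in only one place, so the numbers give no single step to lean on.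

The next compound, compound 4 `O=C1CSC(c2ccc(O)cc2)N1CCN1CCCCC1`, differs from compound 3 in one place: 4-hydroxyphenyl in place of 3-chlorophenyl on a saturated ring carbon. Within the data shown here, no measured step tells what this exchange does on the shared core. Among the measured compounds shown here, the only hint is that compound 2, which carries a 4-methoxyphenyl on the same saturated ring carbon, gives 89%, somewhat below compound 3. The step of a number 8 percentage points lower from compound 3 to compound 4 (within the scatter) is therefore expected to be small, downward, at or just beyond the edge of the scatter. For compound 4 the estimate is 92%, with a range from 78% to 102%.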

Compound 4, a percentage reported as activity, at one concentration (the size of the read-out at that concentration, not a potency): 94%
Compound 4: the middle estimate sits 2 percentage points below what was measured; the measured number falls inside the stated range.
By their numbers in this assay, from the lowest: compound 1; then compounds 2, 4 and 3 (each within the scatter of the next, the first and the last beyond it).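

The read-out of this assay gives a number 6 percentage points lower from compound 3 to compound 4 (within the scatter) when 4-hydroxyphenyl takes the place of 3-chlorophenyl on the saturated ring carbon, so this exchange of aromatic groups, which brings in a hydrogen-bond donor and acceptor, gives no change that can be told from scatter. Hydrogen in place of methyl on the oxygen on the aromatic ring gives a number 5 percentage points higher from compound 2 to compound 4 (within the scatter) and so the hydroxyl and methoxy forms also cannot be told apart in this assay here. No measured property or other outside finding bears on either step.

Going by these compounds, whether an amine or a carboxylic acid on the aromatic ring would give a step beyond the scatter remains open. Also open, on these data alone, is what a change at the ring atom that bears the group of 8 heavy atoms would do.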